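Ester for Amide on Two Related Cores

A few compounds are considered here, and "the series" means these few. Any claim that something is new, unique, unknown or untested is made for them only; others in the source may bear on it.

Compound 1, `CNC(=O)/C=C/c1ccncc1-c1ccc2ccccc2c1`, gives 12.4 nM in an assay on a protein complex for inhibition of CDK8/Cyclin C (Homo sapiens), with a stated time of 1 h; a lower number here means a stronger inhibitor, a higher number a weaker inhibitor. Compound 2, `CNC(=O)/C=C/c1ccncc1-c1ccc2cc[nH]c2c1`, gives 18.6 nM in this assay. Compound 3, `CCOC(=O)/C=C/c1ccncc1-c1ccc2ccccc2c1`, gives 53.3 nM in this assay.

Compound 3 differs from compound 1 by ethoxy in place of methylamino on a carbonyl carbon, and this change made a step of a 4.3-fold higher number from compound 1 to compound 3 (0.63 log units; beyond the scatter). Compound 2 stands on a different core; how its core differs from that of compound 1 is not broken down here. Its value lies close to that of compound 1 and within the usual scatter of it, so the two are not separated in this assay.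

Compound 4, `CCOC(=O)/C=C/c1ccncc1-c1ccc2cc[nH]c2c1`, is the unmeasured member of the set. It differs from compound 2 by ethoxy in place of methylamino on a carbonyl carbon, at a place described in exactly the same words as for the pair of compound 1 and compound 3, so the two changes are the same change made on the two cores.

For compound 4 in this assay the expected step from compound 2 is a 4.3-fold higher number from compound 2 to compound 4 (0.63 log units; beyond the scatter), set beside the measured step because a 4.3-fold higher number from compound 1 to compound 3 (0.63 log units; beyond the scatter) came from the same change. Compound 4 is therefore estimated at 80 nM, with a likely range from 35 nM to 180 nM.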

Compound 4, half-maximal inhibitory concentration: 12.1 nM
The estimate for compound 4 lay 6.6-fold (0.82 log units) above the measured number; measured number outside the range, below it.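

In this assay, ethoxy in place of methylamino on a carbonyl carbon did not have the same outcome on the two cores, and the two steps differ: the same change on two cores in this assay, a 4.3-fold higher number (0.63 log units; beyond the scatter) from compound 1 to compound 3 and a 1.5-fold lower number (0.19 log units; within the scatter) from compound 2 to compound 4, 6.6-fold (0.82 log units) apart, beyond the scatter of two such steps. On the core of compound 2 the change gives a 1.5-fold lower number from compound 2 to compound 4 (0.19 log units; within the scatter), which leaves that pair unseparated, whereas on the core of compound 1 it gives a 4.3-fold higher number from compound 1 to compound 3 (0.63 log units; beyond the scatter). The outcome of this change therefore did not carry from one core to the other in these compounds, but a single pair on each core does not show what sets the two apart, or how the change would behave on any further core.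

The compounds shown leave open whether a methyl ester or a carboxylic acid on the same carbonyl carbon would follow the pattern of the core of compound 1 or that of the core of compound 2. Also open, from the compounds shown here alone, is how a primary amide or an amide with a longer chain on its nitrogen would behave on each core.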